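Swapping the cyclobutyl on compound 1 for an isobutyl

This account rests on a few compounds, and the source may have more. Where it says the series, first, only, none or still open, it means among the compounds named here.

The account concerns two measured compounds and one that is still to be tested. Compound 1 `O=C(O)c1cc(-c2cccc(COc3ccc4c(=O)n(C5CCC5)sc4c3)c2)ccc1Cl` and compound 2 `COc1ccc(-c2cccc(COc3ccc4c(c3)CN(C3CCCC3)C4=O)c2)cc1C(=O)O` were both examined in an ADME assay on microsomes from liver (Rattus norvegicus) for metabolic stability, read by LC-MS, with a stated time of 1 h, at 37 degrees C, tested at 4 uM; a higher number here means that more of the compound is left, a lower number that less of the compound is left. There compound 1 gives 67%, which is the lower of the two numbers; compound 2 gives 84%, a value that lies beyond the usual scatter above the figure for compound 1. Compound 2 differs from compound 1 in several places at once, so these two values show only where each stands, not what any single change does.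

The step that is followed here leads from compound 1 to compound 3 `CC(C)Cn1sc2cc(OCc3cccc(-c4ccc(Cl)c(C(=O)O)c4)c3)ccc2c1=O`. Among the measured compounds shown here, the one change is isobutyl in place of cyclobutyl on an aromatic nitrogen. For the measured compounds named here, no measured pair in this set shares the same change, so there is nothing to lean on beyond the value of compound 1 itself. In this assay a step from compound 1 to compound 3 of a number 7 percentage points lower from compound 1 to compound 3 (within the scatter) is expected, that is, nothing beyond the scatter in either direction. Compound 3 is estimated at 60%, with a range from 40% to 80%.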

Compound 3, percent of the compound remaining: 86%
Beside the measured number, compound 3's estimate is 26 percentage points below it; the whole stated range lies below it.
By their numbers in this assay, from the lowest: compound 1; then compounds 2 and 3 (each within the scatter of the next).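

Isobutyl in place of cyclobutyl on an aromatic nitrogen, next to the ring sulfur, gives a number 19 percentage points higher from compound 1 to compound 3 (beyond the scatter) in this assay, and this is the first step in the set that isolates a single place. It shows that the read-out at this position depends on more than the size of the group counted in atoms, for cyclobutyl and isobutyl each hold 4 heavy atoms (4 carbon), with 0 hydrogen-bond donors, 0 hydrogen-bond acceptors and no net charge, and what differs in these counts is that one four-membered non-aromatic ring gives way to no ring. Nothing measured here accounts for the size of this step.

On these data alone, the step rests on one pair, so whether it belongs to open chains in general or to isobutyl alone remains open, as does whether it would carry over to the core of compound 2. How a longer chain, or a chain ending in an amine or an ether oxygen, would fare on this nitrogen also remains to be seen.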